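Swapping the Aryl Group on a Shared Core

The source may report more compounds than this note shows. Statements on the series, on what has been measured and on what is new or still open speak of the compounds shown alone.

Compound 1 `CC(=O)c1ccc(-c2cn3ccnc3c(-c3ccc4ncn(C5CCCCC5)c4c3)n2)cc1` was tested in a functional assay on SF-539 cells (Homo sapiens) for inhibition, read by sulforhodamine B assay, with a stated time of 48 h, tested at 10 uM (on this read-out lower numbers stand for less inhibition and higher numbers for more inhibition at the one concentration tested (going by the name of the read-out)), where compound 1 gives 2.82%. Compound 2 `Clc1ccc(-c2cn3ccnc3c(-c3ccc4ncn(C5CCCCC5)c4c3)n2)cc1` shares the same core and differs only in the group on the outer ring; in this assay compound 2 gives 6.3%. The change between them, chloro in place of acetyl on an aromatic carbon, gives a number 3.5 percentage points higher from compound 1 to compound 2 (within the scatter). Compound 2 therefore holds the higher of the two numbers, but its gap to compound 1 is within the scatter, so the two cannot be told apart.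

Compound 3 `Fc1ccccc1-c1cn2ccnc2c(-c2ccc3ncn(C4CCCCC4)c3c2)n1` is not yet measured. It differs from compound 2 as follows: 2-fluorophenyl in place of 4-chlorophenyl on an aromatic carbon. Among the measured compounds shown here, no measured step swaps one such aryl group for another, so the only guide is that both known compounds sit low and close together. The step expected here is a number 1.3 percentage points lower from compound 2 to compound 3 (within the scatter), nothing beyond the scatter. For compound 3 the estimate in this assay is 5%, within a range from -5% to 15%.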

Compound 3, a percentage reported as inhibition, at one concentration (the size of the read-out at that concentration, not a potency): 4.51%
Compound 3: middle estimate off by 0.5 percentage points, on the high side; the range from low to high includes it.
By their numbers in this assay, from the lowest: compounds 1, 3 and 2 (each within the scatter of the next).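

Replacing 4-chlorophenyl with 2-fluorophenyl changes both the halogen and its place on the outer ring, yet this assay shows a number 1.8 percentage points lower from compound 2 to compound 3 (within the scatter) for this swap, and replacing 4-acetylphenyl with 2-fluorophenyl gives a number 1.7 percentage points higher from compound 1 to compound 3 (within the scatter) on the same aromatic carbon. The 2-fluorophenyl group therefore cannot be told apart from either of the other two groups, so this small set gives no ranking among the three aryl groups at this position. No outside evidence bears on this result.

A 4-fluorophenyl group would separate the change of halogen from the change of its place on the ring. Going by these compounds, it also remains open whether a different kind of group on the outer ring, such as an amine or a carboxylic acid, would give a clearly different number.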